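Aryl urea series: bromo to methoxy on the aryl ring

The source may report more compounds than this note shows. Statements on the series, on what has been measured and on what is new or still open speak of the compounds shown alone.

Measured compounds:
compound 1 `O=C(Nc1ccc(Br)cc1)N[C@H]1CC[C@H](Oc2ccc(F)cc2)CC1` — > 20000 nM
compound 2 `CSc1ccc(NC(=O)N[C@H]2CC[C@H](Oc3ccc(F)cc3)CC2)cc1` — > 20000 nM
compound 3 `Cc1cccc(NC(=O)N[C@H]2CC[C@H](Oc3ccc(F)cc3)CC2)c1` — 14400 nM

The read-out is a functional assay on CRL2813 cells (Homo sapiens) for cytotoxicity, read by sulforhodamine B assay, with a stated time of 5 days; a higher number here means a weaker inhibitor, a lower number a stronger inhibitor. Compound 1 sits at a limit of the assay, > 20000 nM, which is not a number. Compound 2 also sits at a limit, > 20000 nM. Compound 3 gives a number, 14400 nM. Compound 1 therefore stands at the limit of > 20000 nM in this assay, at which 2 of the 3 values shown sit; on these figures it cannot be placed relative to compound 2, and the gap to compound 3 is known only as a floor.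

Compound 4 `COc1ccc(NC(=O)N[C@H]2CC[C@H](Oc3ccc(F)cc3)CC2)cc1` differs from compound 1 as methoxy in place of bromo on an aromatic carbon. Within the data shown here, two measured steps bear on it. The first changes the same position: a step that the two limits leave unreadable from compound 1 to compound 2. The second changes the whole aryl group: an at least 1.3-fold lower number from compound 1 to compound 3 (0.14 log units; that floor lies within the scatter). Neither gives a readable direction beyond the scatter, and both start from the limit. No step beyond the scatter is therefore expected in this assay for compound 4, and the likeliest outcome is another value at or near the limit. The estimate for compound 4 is 22000 nM, within 8000 nM to 60000 nM. The expected step is a step that the limit leaves unreadable from compound 1 to compound 4.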

Compound 4, half-maximal inhibitory concentration: > 20000 nM
Compound 4: no number, only a limit; the forecaster's own chance of this, stated with the estimate: 60%; the middle value is on the limit's open side.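

In this assay, compound 4 gives > 20000 nM, which is a limit of the assay and not a number. With methoxy, a third group para to a large group ends at the same place, so this position has yet to give a number with bromo, methylsulfanyl or methoxy: the limit of > 20000 nM in this assay, at which 3 of the 4 values shown sit.

Among these compounds, the only readable comparison is an at least 1.3-fold higher number from compound 3 to compound 4 (0.14 log units; that floor lies within the scatter), while the steps among compound 1, compound 2 and compound 4 cannot be read.

On these data alone, whether an amine or a carboxylic acid in place of methoxy at this position would give a number rather than a limit stays open. Among the compounds shown here, compound 3 gives 14400 nM, the only number in the set. The compounds shown cannot tell whether the 3-methylphenyl group truly separates compound 3 from the limit.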